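This account rests on a few compounds, and the source may have more. Where it says the series, first, only, none or still open, it means among the compounds named here.

Measured in a functional assay on K562 cells (Homo sapiens) for antiproliferative activity, read by MTT assay, with a stated time of 72 h; on this read-out higher numbers stand for weaker inhibition and lower numbers for stronger inhibition:
Compound 1 `COc1cc(-c2ncnn2-c2cccc(N)c2)cc(OC)c1OC`: > 10000 nM (a limit)
Compound 2 `COc1ccc(-c2ncnn2-c2cc(OC)c(OC)c(OC)c2)cc1`: 950 nM
Compound 3 `COc1cc(-n2ncnc2-c2ccc(OC(F)(F)F)cc2)cc(OC)c1OC`: > 10000 nM (a limit)

Compound 1 has no number on this scale. Its > 10000 nM is a limit of this assay. Compound 3 also stands at a limit, so compound 2 is the only one of the three with a numerical value. The data therefore gather at the limit of > 10000 nM in this assay, at which 2 of the 3 values shown sit.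

Compound 4 `COc1cc(-c2ncnn2-c2ccccc2)cc(OC)c1OC` differs from compound 1 by a single change, hydrogen in place of amino on an aromatic carbon, which turns 3-aminophenyl into phenyl.

Among the compounds with values here, no measured step covers this change. Within the data shown here, the only step available is an at least 10-fold higher number from compound 2 to compound 3 (1.02 log units; beyond the scatter), and it comes from trifluoromethyl in place of methyl on an oxygen on an aromatic ring. It shows that one change can be large in this assay, but it gives no size or direction for the loss of amino.

With no guide to a gain, compound 4 is expected to stay close to the limit held by compound 1. The expected result is a number no higher from compound 1 to compound 4 (the limit leaves the size open), so no step beyond the scatter is anticipated. For compound 4 the estimated value is 10000 nM, with an expected range from 2000 nM to 30000 nM.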

Compound 4, half-maximal inhibitory concentration: > 10000 nM
Compound 4 gave a limit, no number (the forecaster's own chance of this, stated with the estimate: 65%); the middle value sits exactly at the limit.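

In this assay compound 4 gives > 10000 nM, a limit and not a number. Compound 1 also stands at a limit, and the step between compound 1 and compound 4 cannot be read. The compounds shown leave open whether hydrogen in place of amino changes the antiproliferative activity at all.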